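Cytotoxicity notes on a shared-core amide series

This account rests on a few compounds, and the source may have more. Where it says the series, first, only, none or still open, it means among the compounds named here.

Measured compounds in an ADME assay on L02 cells (Homo sapiens) for cytotoxicity, read by MTT assay, with a stated time of 72 h; on this read-out lower numbers stand for stronger inhibition and higher numbers for weaker inhibition:
- compound 1 `CCC/C=C/C(=O)Nc1cccc(Oc2nc(Nc3cccc(OC)c3)nc3c2CSCC3)c1`: compound 1 gives > 50000 nM, a limit of this assay.
- compound 2 `COc1cccc(Nc2nc3c(c(Oc4cccc(NC(=O)C=C(C)C)c4)n2)CSCC3)c1`: compound 2 gives > 50000 nM, a limit of this assay.
- compound 3 `CCC/C=C/C(=O)Nc1cccc(Oc2nc(Nc3cccc(C#N)c3)nc3c2CSCC3)c1`: compound 3 gives > 50000 nM, a limit of this assay.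

All three values sit at the same limit, so no ordering among compound 1, compound 2 and compound 3 can be read from this assay. The change from compound 1 to compound 2 is 2-methylprop-1-en-1-yl in place of pent-1-en-1-yl on a carbonyl carbon; the step it made, a step that the two limits leave unreadable from compound 1 to compound 2, has no readable size. The change from compound 1 to compound 3 is cyano in place of methoxy on an aromatic carbon; its step, a step that the two limits leave unreadable from compound 1 to compound 3, is likewise unreadable.

Compound 4 `CC(C)=CC(=O)Nc1cccc(Oc2nc(Nc3cccc(C#N)c3)nc3c2CSCC3)c1` is not yet measured in this assay. It differs from compound 3 by 2-methylprop-1-en-1-yl in place of pent-1-en-1-yl on a carbonyl carbon, which is the same change as that from compound 1 to compound 2, made at the same place. The cores of compound 3 and compound 4 carry the cyano group, and this core difference from compound 1 is the one counted above.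

For compound 4 the step from compound 3 is expected to be a step that the limit leaves unreadable from compound 3 to compound 4, resting on the limit of > 50000 nM in this assay, at which 3 of the 3 values shown sit, and on the unreadable step that the two limits leave unreadable from compound 1 to compound 2 for the same change. Compound 4 is estimated at 80000 nM, with a likely range from 40000 nM to 200000 nM, most probably again reported only as a limit.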

Compound 4, half-maximal inhibitory concentration: > 50000 nM
Compound 4 gave a limit, no number; the forecaster's own chance of this, stated with the estimate: 85%; the middle value lies beyond the limit too.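

No new step can be read for compound 4: its steps from compound 3 and from compound 2 each run between two limits, so neither has a size. In this assay the series offers no number to compare: the limit of > 50000 nM in this assay, at which 4 of the 4 values shown sit.

The compounds shown leave open whether cyano in place of methoxy, or 2-methylprop-1-en-1-yl in place of pent-1-en-1-yl, changes cytotoxicity in these cells at all.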